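From a free amino group to diethylamino

The source may hold more compounds than are shown below. What is called first, only, known or untested is meant among the compounds shown, and "the series" means these compounds.

Compound 1 `CCC(=O)N(c1ccc(Cl)c(Cl)c1)C1CCCC1O`: 0.4 mg/kg
Compound 2 `CCC(=O)N(c1ccc(C(=O)OC)cc1)C1CCCC1N(C)C`: > 50 mg/kg (a limit)
Compound 3 `CCC(=O)N(c1ccc(Cl)c(Cl)c1)C1CCCC1N`: 0.02 mg/kg

In a functional assay on the whole organism for positive allosteric modulation, with Mus musculus as the target (on this read-out higher numbers stand for an effect only at larger amounts of compound and lower numbers for an effect already at smaller amounts), compound 3 has the lowest number, 0.02 mg/kg, and its nearest neighbour is compound 1. Compound 4 `CCC(=O)N(c1ccc(Cl)c(Cl)c1)C1CCCC1N(CC)CC` has diethylamino in place of amino on a saturated ring carbon. Among the measured compounds shown here, the only measured step at this carbon is a 20-fold lower number from compound 1 to compound 3 (1.30 log units; beyond the scatter), a large one, so changes here can matter. Compound 2, which also has a substituted amino group on this carbon, gives only a limit, > 50 mg/kg. The expected change is a 25-fold higher number from compound 3 to compound 4 (1.40 log units; beyond the scatter), towards a higher number and beyond the scatter. The estimated value for compound 4 is 0.5 mg/kg, with an expected range of 0.04 mg/kg to 10 mg/kg.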

Compound 4, dose for half-maximal effect: 0.1 mg/kg
Compound 4: middle estimate off by 5.0-fold (0.70 log units), on the high side; measured number inside the range.
By their numbers in this assay, from the lowest: compound 3; then compound 4; then compound 1. At a limit, above all of these: compound 2.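

Adding two ethyl groups to the amino group moves the number up only modestly: in this assay there is a 5.0-fold higher number from compound 3 to compound 4 (0.70 log units; beyond the scatter). The result stays on the favourable side of the hydroxy compound, with a 4.0-fold lower number from compound 1 to compound 4 (0.60 log units; beyond the scatter). So the hydrogen-bond donor of amino is not required for a number lower than hydroxy gives, and this carbon accepts the much larger diethylamino.

Going by these compounds, it remains open whether methylamino or dipropylamino here would follow the same trend. Compound 2 differs from compound 4 in more than one place and gives only a limit: the limit of > 50 mg/kg in this assay, at which 1 of the 4 values shown sits.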